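Urea in Place of Amide on a Pyrazole Scaffold

This account rests on a few compounds, and the source may have more. Where it says the series, first, only, none or still open, it means among the compounds named here.

Measured compounds:
compound 1 `COc1cc(-c2nn(-c3cccc(NC(=O)c4ccc(Cl)c(C(F)(F)F)c4)c3)cc2-c2ccncc2)ccc1Cl`, > 32500 nM
compound 2 `O=C(Nc1cccc(-n2cc(-c3ccncc3)c(-c3ccc(Cl)c(O)c3)n2)c1)Nc1cc(C(F)(F)F)cc(C(F)(F)F)c1`, 4110 nM

Of the compounds shown here, two have been tested in a functional assay on BT-549 cells (Homo sapiens) for inhibition, read by sulforhodamine B assay, with a stated time of 48 h; on this read-out higher numbers stand for lower toxicity in this test and lower numbers for higher toxicity in this test. Compound 1 `COc1cc(-c2nn(-c3cccc(NC(=O)c4ccc(Cl)c(C(F)(F)F)c4)c3)cc2-c2ccncc2)ccc1Cl` reaches only a limit there, > 32500 nM, which is the edge of what the test reports rather than a measured number; this is what the limit of > 32500 nM in this assay, at which 1 of the 2 values shown sits, records. Compound 2 `O=C(Nc1cccc(-n2cc(-c3ccncc3)c(-c3ccc(Cl)c(O)c3)n2)c1)Nc1cc(C(F)(F)F)cc(C(F)(F)F)c1` carries a urea linker and differs from compound 1 in more than one place. In this assay compound 2 gives a number, 4110 nM.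

The unmeasured compound 3 `COc1cc(-c2nn(-c3cccc(NC(=O)Nc4ccc(Cl)c(Cl)c4)c3)cc2-c2ccncc2)ccc1Cl` keeps the core of compound 1 and changes one spot: (3,4-dichlorophenyl)amino in place of 4-chloro-3-(trifluoromethyl)phenyl on a carbonyl carbon. A urea analogue, compound 2, gave a measured value, so a shift toward a measurable, lower number is expected for compound 3, with the step from compound 1 estimated at an at least 3.6-fold lower number from compound 1 to compound 3 (0.55 log units; beyond the scatter). Compound 3 is therefore expected near 9000 nM in this assay, estimated between 2500 nM and 32500 nM.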

Compound 3, concentration lethal to 50% of the cells: > 50000 nM
Compound 3 was reported as a limit; the forecaster's own chance of this, stated with the estimate: 35%; middle value at least 5.5-fold (0.74 log units) from the limit.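

Compound 1 and compound 3 both stand only as limits, so the step from one to the other cannot be read. Left open is whether this change of group shifts the value at all, and which differences from compound 1 go with the measured value of compound 2, 4110 nM.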